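Compound 3 to compound 4: oxazole replaces phenyl

This account rests on a few compounds, and the source may have more. Where it says the series, first, only, none or still open, it means among the compounds named here.

Compound 3 `Cc1ccc(OCC(=O)N(Cc2cccs2)c2ccccc2)cc1` gives the lowest number of the three measured in an assay on HEK293 cells for agonist activity at transient receptor potential cation channel subfamily M member 8 (Homo sapiens), read by fluorescence and calcium flux, with a stated time of 15 min (on this read-out lower numbers stand for an effect already at smaller amounts and higher numbers for an effect only at larger amounts of compound), namely 23 nM. Compound 2 `Cc1ccc(OCC(=O)N(Cc2cccs2)c2ccncc2)cc1` gives 52 nM, and compound 1 `Cc1ccc(OCC(=O)N(Cc2cccs2)c2ncccn2)cc1` gives 3700 nM. Compound 4 `Cc1ccc(OCC(=O)N(Cc2cccs2)c2ncco2)cc1` differs from compound 3 by 1,3-oxazol-2-yl in place of phenyl on an amide-type nitrogen. For the measured compounds named here, two measured steps bear on this change, since each replaces a ring containing nitrogen by phenyl: a 160-fold lower number from compound 1 to compound 3 (2.21 log units; beyond the scatter) and a 2.3-fold lower number from compound 2 to compound 3 (0.35 log units; beyond the scatter). Reversing that direction, compound 4 is expected to give a higher number, probably a large step, though the size is uncertain because the step of a 160-fold lower number from compound 1 to compound 3 (2.21 log units; beyond the scatter) is far larger than a 2.3-fold lower number from compound 2 to compound 3 (0.35 log units; beyond the scatter). The estimate for compound 4 is 500 nM, within 60 nM to 5000 nM. For compound 4 this expectation means a 22-fold higher number from compound 3 to compound 4 (1.34 log units; beyond the scatter).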

Compound 4, half-maximal effective concentration: 0.3 nM
Compound 4: middle estimate off by 1700-fold (3.22 log units), on the high side; the measured number lies below the stated range.
By their numbers in this assay, from the lowest: compound 4; then compound 3; then compound 2; then compound 1.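

At the amide-type nitrogen, the earlier rings containing nitrogen had only given higher numbers than phenyl, whereas 1,3-oxazol-2-yl reverses that direction in this assay (a 77-fold lower number from compound 3 to compound 4 (1.88 log units; beyond the scatter)). It also separates sharply from the other two rings containing nitrogen (a 170-fold lower number from compound 2 to compound 4 (2.24 log units; beyond the scatter); a 12000-fold lower number from compound 1 to compound 4 (4.09 log units; beyond the scatter)), so having nitrogen in the ring does not alone set the direction of the step. Nothing available here accounts for this reversal. The compounds leave open whether the low number is specific to 1,3-oxazol-2-yl or extends to another five-membered aromatic ring, such as 1,3-thiazol-2-yl, which carries sulfur in place of the ring oxygen.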